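The compounds below may be only part of what the source reports. "The series", "measured", "known", "first", "only" and "open" are said of these compounds alone.

Notes on the series. In an assay on HEK293 cells for agonist activity at Bile acid receptor (Homo sapiens), read by a luciferase reporter (on this read-out higher numbers stand for larger maximal responses and lower numbers for smaller maximal responses), compound 2 `CC(C)OC(=O)C1=CN(C(=O)c2ccc(F)c(F)c2)CC(C)(C)c2cc(C#N)[nH]c21` gives 121%, compound 3 `CC(C)OC(=O)C1=CN(C(=O)c2ccc(F)cc2)CC(C)(C)c2cc(C#N)[nH]c21` gives 119%, and compound 1 `CC(C)OC(=O)C1CN(C(=O)c2ccc(F)cc2)CC(C)(C)c2cc(C#N)[nH]c21` gives 85%; compound 2 and compound 3 sit within the scatter of each other, while compound 1 lies beyond the scatter below both. Compound 4 `CC(C)OC(=O)C1=CN(C(=O)c2cccc(C(F)(F)F)c2)CC(C)(C)c2cc(C#N)[nH]c21` is not yet measured. It differs from compound 2 by 3-(trifluoromethyl)phenyl in place of 3,4-difluorophenyl on a carbonyl carbon. Within the data shown here, the only measured step on that aromatic ring is a number 2 percentage points lower from compound 2 to compound 3 (within the scatter), so the one change of a ring substituent on record left this assay essentially unmoved. On that basis no step beyond the scatter is expected for the larger exchange of 3-(trifluoromethyl)phenyl for 3,4-difluorophenyl, so a number 6 percentage points lower from compound 2 to compound 4 (within the scatter) is the estimate. Compound 4 is therefore expected to give about 115%, most likely between 95% and 135%.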

Compound 4, largest response reached (reported as efficacy), in percent of the reference or control that the assay uses: 94%
Estimate against measurement, compound 4: 21 percentage points above; the measured number lies below the stated range.
By their numbers in this assay, from the lowest: compounds 1 and 4 (each within the scatter of the next); then compounds 3 and 2 (each within the scatter of the next).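

In this assay the aromatic ring on the carbonyl carbon proves less forgiving than a number 2 percentage points lower from compound 2 to compound 3 (within the scatter) alone suggested. Exchange of 3,4-difluorophenyl for 3-(trifluoromethyl)phenyl gives a number 27 percentage points lower from compound 2 to compound 4 (beyond the scatter) and exchange of 4-fluorophenyl for the same group gives a number 25 percentage points lower from compound 3 to compound 4 (beyond the scatter) so the response here depends on the ring substituent, at least for this one exchange. Nothing at hand accounts for this loss of maximal response.

As far as these compounds go, what a chloro or methoxy substituent on this ring would do remains open. Also open, from the compounds shown here alone, is whether a plain phenyl would keep the response of the fluorinated rings.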